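The source may report more compounds than this note shows. Statements on the series, on what has been measured and on what is new or still open speak of the compounds shown alone.

The series shares one core, varied at a single aromatic carbon of the benzyl arm. Compound 1 `Cc1ccc2[nH]c(=O)c(CN(Cc3ccccc3)Cc3ccc(C(C)(C)C)cc3)cc2c1` carries a hydrogen there. In a toxicity assay on MDCK cells (Canis lupus familiaris) for cytotoxicity, read by crystal violet staining, with a stated time of 48 h (on this read-out lower numbers stand for higher toxicity in this test and higher numbers for lower toxicity in this test), compound 1 reads only as a limit, > 5000 nM. Compound 2 `COCOc1ccc(CN(Cc2ccc(C(C)(C)C)cc2)Cc2cc3cc(C)ccc3[nH]c2=O)cc1` carries a methoxymethoxy group at that carbon; in this assay compound 2 gives 6400 nM. Compound 3 `Cc1ccc2[nH]c(=O)c(CN(Cc3ccc(C(N)=O)cc3)Cc3ccc(C(C)(C)C)cc3)cc2c1` carries a carbamoyl there; in this assay compound 3 again sits at a limit, > 5000 nM. Compound 3 thus stands at the limit together with one other value of the three, and no number separates it from either neighbour: the steps a step that the two limits leave unreadable from compound 1 to compound 3 and a step that the limit leaves unreadable from compound 2 to compound 3 cannot be sized, nor can a step that the limit leaves unreadable from compound 1 to compound 2, since (the limit of > 5000 nM in this assay, at which 2 of the 3 values shown sit).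

Compound 4 `Cc1ccc2[nH]c(=O)c(CN(Cc3ccc(SC(F)F)cc3)Cc3ccc(C(C)(C)C)cc3)cc2c1` is the next member; it differs from compound 3 in that ((difluoromethyl)sulfanyl in place of carbamoyl on an aromatic carbon). Of the measured steps only those ending at compound 3 bear on this change, and both are unreadable, so they give neither size nor direction. Within the data shown here, the three values so far sit at or near the limit, so in this assay no step beyond the scatter is expected, a step that the limit leaves unreadable from compound 3 to compound 4. Compound 4 is therefore expected at 8000 nM, within 3000 nM to 30000 nM, with a fair chance that only a limit is returned.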

Compound 4, half-maximal cytotoxic concentration: > 5000 nM
Compound 4 ended at the assay's limit (the forecaster's own chance of this, stated with the estimate: 60%); the middle value lies beyond the limit too.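

Among these compounds, compound 4 joins compound 1 and compound 3 at the limit, so no step to compound 4 from compound 1, compound 2 or compound 3 can be read: the limit of > 5000 nM in this assay, at which 3 of the 4 values shown sit. The compounds shown leave open whether any of these groups at this aromatic carbon changes the half-maximal cytotoxic concentration, and in which direction.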